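Amide-to-sulfonamide exchange on the ring nitrogen

The source may hold more compounds than are shown below. What is called first, only, known or untested is meant among the compounds shown, and "the series" means these compounds.

Three compounds of the series have numbers in a functional assay on SMMC-7721 cells (Homo sapiens) for antiproliferative activity, read by MTT assay, with a stated time of 72 h; on this read-out lower numbers stand for stronger inhibition and higher numbers for weaker inhibition. In this assay compound 1 `CCC(=O)N(C)c1ccc2[nH]c(-c3n[nH]c4ccccc34)cc2n1` gives 33500 nM. In this assay compound 2 `CN(C(=O)CCc1ccccc1)c1ccc2[nH]c(-c3n[nH]c4ccccc34)cc2n1` gives 20900 nM. In this assay compound 3 `COc1ccc(C(=O)N(C)c2ccc3[nH]c(-c4n[nH]c5ccccc45)cc3n2)cc1` gives 23700 nM. The three numbers sit close together: the step of a 1.6-fold lower number from compound 1 to compound 2 (0.20 log units; within the scatter), the step of a 1.4-fold lower number from compound 1 to compound 3 (0.15 log units; within the scatter) and the step of a 1.1-fold higher number from compound 2 to compound 3 (0.05 log units; within the scatter) all stay within the scatter, so none of the three can be called stronger or weaker than another. Compound 3 stands second highest of the three, nearest compound 2 and furthest from compound 1.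

Compound 4 `CN(c1ccc2[nH]c(-c3n[nH]c4ccccc34)cc2n1)S(=O)(=O)c1ccccc1` has not been measured. Relative to compound 3 the change is phenylsulfonyl in place of (4-methoxyphenyl)carbonyl on a nitrogen on an aromatic ring. The measured steps that bear on it are those that also exchange the group on the same nitrogen: a 1.4-fold lower number from compound 1 to compound 3 (0.15 log units; within the scatter) and a 1.1-fold higher number from compound 2 to compound 3 (0.05 log units; within the scatter), both within the scatter. Among the measured compounds shown here, no measured step replaces the carbonyl itself by a sulfonyl, so that part of the change has no precedent. For the measured compounds named here, since every exchange at this position so far has left this assay flat, no step beyond the scatter is expected for compound 4 in either direction. Compound 4 is therefore estimated at 24000 nM, with a range from 8000 nM to 70000 nM, which amounts to an expected step of a 1.0-fold higher number from compound 3 to compound 4 (0.01 log units; within the scatter).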

Compound 4, half-maximal inhibitory concentration: 12000 nM
Beside the measured number, compound 4's estimate is 2.0-fold (0.30 log units) above it, within the range that was stated.
By their numbers in this assay, from the lowest: compounds 4, 2, 3 and 1 (each within the scatter of the next, the first and the last beyond it).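

In this assay, among the compounds shown here, the exchange on the nitrogen on an aromatic ring now gives its only step beyond the scatter, a modest one: with phenylsulfonyl in place of propanoyl, the step is a 2.8-fold lower number from compound 1 to compound 4 (0.45 log units; beyond the scatter). Against the two larger acyl groups the same sulfonyl gives no separable result, with phenylsulfonyl in place of (4-methoxyphenyl)carbonyl at a 2.0-fold lower number from compound 3 to compound 4 (0.30 log units; within the scatter) and in place of phenethylcarbonyl at a 1.7-fold lower number from compound 2 to compound 4 (0.24 log units; within the scatter), so the position is no longer entirely flat, but the sulfonamide stands apart only from the propanoyl amide. No measurement on hand explains the step from compound 1 to compound 4.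

The step from compound 3 to compound 4 swaps the carbonyl for a sulfonyl and removes the methoxy group at once, so the compounds shown leave the share of each change open; a 4-methoxyphenylsulfonyl group or a plain benzoyl group on the same nitrogen would separate the two. Also open, going by these compounds, is whether the sulfonyl carries the step without an aromatic ring on it, as a methylsulfonyl or a longer alkylsulfonyl chain would show.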